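The source may hold more compounds than are shown below. What is called first, only, known or untested is meant among the compounds shown, and "the series" means these compounds.

In an ADME assay on microsomes (Homo sapiens) for metabolic stability (a higher number here means faster removal of the compound, a lower number slower removal), compound 1 `CNC(=O)[C@@H]1CCCN1S(=O)(=O)c1ccc(Cl)c(COc2cccc3c(-n4ccnc4)cc(C)nc23)c1Cl` gives 33.3 mL/min/kg, the lowest of three measured numbers and beyond the scatter of both others. Compound 3 `Cc1cc(C(F)(F)F)c2cccc(OCc3c(Cl)ccc(S(=O)(=O)N4CCC[C@H]4C(N)=O)c3Cl)c2n1` gives 167 mL/min/kg, and compound 2 `CCc1cc(C(F)(F)F)c2cccc(OCc3c(Cl)ccc(S(=O)(=O)N4CCC[C@H]4C(=O)NC)c3Cl)c2n1` gives 300 mL/min/kg. Neither compound 2 nor compound 3 carries 1H-imidazol-1-yl, but both also differ from compound 1 elsewhere, and no single change has been measured. Compound 4 `CNC(=O)[C@@H]1CCCN1S(=O)(=O)c1ccc(Cl)c(COc2cccc3c(OCc4ccccc4)cc(C)nc23)c1Cl` has benzyloxy in place of 1H-imidazol-1-yl on an aromatic carbon, opposite the ring nitrogen: benzyloxy in place of 1H-imidazol-1-yl on an aromatic carbon. With only those higher numbers as a guide, a rise beyond the scatter is expected in this assay. The estimated step is a 3.3-fold higher number from compound 1 to compound 4 (0.52 log units; beyond the scatter). For compound 4 the estimated clearance is 110 mL/min/kg, with an expected range of 50 mL/min/kg to 240 mL/min/kg.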

Compound 4, clearance: 467 mL/min/kg
The estimate for compound 4 lay 4.2-fold (0.63 log units) below the measured number; measured number outside the range, above it.
By their numbers in this assay, from the lowest: compound 1; then compounds 3, 2 and 4 (each within the scatter of the next, the first and the last beyond it).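

In this assay, benzyloxy in place of 1H-imidazol-1-yl gives a 14-fold higher number from compound 1 to compound 4 (1.15 log units; beyond the scatter), the first single change read in this series. It shows that this aromatic carbon, opposite the ring nitrogen, is not a neutral place on the core of compound 1: the group here alone moves clearance by a large step. Nothing measured here explains the step.

Open, going by these compounds, is whether the rise follows the carbon-only aromatic ring or the ether oxygen of benzyloxy. A methoxy group or a phenyl ring at this position would separate the two.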